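Cyclopropyl in Place of Ethyl on the Shared Core

A few compounds are considered here, and "the series" means these few. Any claim that something is new, unique, unknown or untested is made for them only; others in the source may bear on it.

Measured compounds:
compound 1 `OC(Cc1ccccc1)c1cccc2[nH]ncc12`: 7900 nM
compound 2 `Cc1cc(C(O)Cc2ccccc2)c2cn[nH]c2c1`: 470 nM
compound 3 `CCc1cc(C(O)Cc2ccccc2)c2cn[nH]c2c1`: 740 nM

In an assay for binding affinity to Indoleamine 2,3-dioxygenase 1 (Homo sapiens), read by spectrophotometry, with a stated time of 30 min (on this read-out higher numbers stand for weaker binding and lower numbers for tighter binding), compound 3 stands second highest of the three numbers. The step of a 1.6-fold higher number from compound 2 to compound 3 (0.20 log units; within the scatter) lies within the scatter, whereas the step of an 11-fold lower number from compound 1 to compound 3 (1.03 log units; beyond the scatter) lies beyond it. Compound 4 `OC(Cc1ccccc1)c1cc(C2CC2)cc2[nH]ncc12` differs from compound 3 by cyclopropyl in place of ethyl on an aromatic carbon. Two kinds of measured step bear on this change: a 17-fold lower number from compound 1 to compound 2 (1.23 log units; beyond the scatter) and an 11-fold lower number from compound 1 to compound 3 (1.03 log units; beyond the scatter) show that an alkyl group at this carbon goes with a much lower number than hydrogen, while a 1.6-fold higher number from compound 2 to compound 3 (0.20 log units; within the scatter) shows that enlarging methyl to ethyl changed little. A cyclopropyl at the same carbon is therefore expected to give no step beyond the scatter in this assay. Compound 4 is estimated at 800 nM, with a range of 250 nM to 2500 nM. That estimate means an expected step of a 1.1-fold higher number from compound 3 to compound 4 (0.03 log units; within the scatter).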

Compound 4, dissociation constant: 1200 nM
Compound 4: the middle estimate sits 1.5-fold (0.18 log units) below what was measured; measured number inside the range.
By their numbers in this assay, from the lowest: compounds 2, 3 and 4 (each within the scatter of the next, the first and the last beyond it); then compound 1.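

In this assay a three-membered ring at this aromatic carbon keeps the much lower number seen with alkyl groups over hydrogen (a 6.6-fold lower number from compound 1 to compound 4 (0.82 log units; beyond the scatter)). Against ethyl, cyclopropyl cannot be told apart (a 1.6-fold higher number from compound 3 to compound 4 (0.21 log units; within the scatter)). Against methyl, it gives the first step among groups at this carbon that leaves the scatter (a 2.6-fold higher number from compound 2 to compound 4 (0.41 log units; beyond the scatter)), so methyl and cyclopropyl are separated while ethyl is within the scatter of both. On these data alone, whether an amine, a methoxy group or a longer chain at this carbon would hold the number remains open. Nothing available explains these differences.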